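A few compounds are considered here, and "the series" means these few. Any claim that something is new, unique, unknown or untested is made for them only; others in the source may bear on it.

Measured so far, in a functional assay on A549 cells (Homo sapiens) for inhibition, read by colorimetric assay and MTT assay, with a stated time of 72 h; on this read-out lower numbers stand for stronger inhibition and higher numbers for weaker inhibition
- compound 1 `Cn1c2cnc1OCCCCCCCCOc1cc3ccccc3cc1-2` gives 26000 nM
- compound 2 `Cn1c2cnc1OCCCCCCCCCCCOc1ccccc1-2` gives 36000 nM
- compound 3 `C=CCCCCOc1ccccc1-c1cnc(OCCCC=C)n1C` gives 3000 nM

Compound 3 has the lowest number of the three, and its gaps to compound 1 and compound 2 both lie beyond the scatter.

The next compound to be read is compound 4 `C=CCCCCOc1ccccc1-c1cnc(OC)n1C`. The change from compound 3 is hydrogen in place of but-3-en-1-yl on a saturated chain carbon bound to an oxygen on an aromatic ring. Cut one bond further out, the same difference reads (pent-4-en-1-yl)oxy to methoxy.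

Within the data shown here, the series holds no measured pair that differs in one place, so the expectation rests on very little. Among the measured compounds shown here, compound 3 at 3000 nM is the only measured compound carrying these open chains, and nothing yet shows what either chain contributes. A moderate step beyond the scatter is expected in this assay, towards a higher number and so weaker inhibition. The estimated change is a 3.7-fold higher number from compound 3 to compound 4 (0.56 log units; beyond the scatter). For compound 4 the expected value is 11000 nM, with an estimated range of 3500 nM to 35000 nM.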

Compound 4, half-maximal inhibitory concentration: 80000 nM
For compound 4 the middle estimate is 7.3-fold (0.86 log units) below the measured one; the measured number lies above the stated range.
By their numbers in this assay, from the lowest: compound 3; then compounds 1 and 2 (each within the scatter of the next); then compound 4.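

Among these compounds, replacing but-3-en-1-yl with hydrogen on a saturated chain carbon bound to an oxygen on an aromatic ring, which turns (pent-4-en-1-yl)oxy into methoxy, gives in this assay a 27-fold higher number from compound 3 to compound 4 (1.43 log units; beyond the scatter), the first single-place comparison. This position is therefore not indifferent in this assay: the open chain of compound 3 cannot be cut back to methoxy without a large loss of inhibition. No measurement at hand accounts for the size of this step.

As far as these compounds go, whether the chain's length or its double bond matters remains open; a saturated butyl chain, a shorter ethyl chain or a longer chain at this place would separate the two. The contribution of the second open chain, shared by compound 3 and compound 4, is also unresolved.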